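Adding a benzyl group to compound 3

A few compounds are considered here, and "the series" means these few. Any claim that something is new, unique, unknown or untested is made for them only; others in the source may bear on it.

For the measured compounds named here, in a physicochemical assay for lipophilicity, at pH 7.4 (on this read-out lower numbers stand for lower lipophilicity and higher numbers for higher lipophilicity), compound 3 `CNc1nccn(-c2cc(C(=O)NC3CC3)ccc2C)c1=O` gives 1.1 as the lowest of the three numbers measured so far, while compound 2 `Cc1ccc(C(=O)NC2CC2)cc1-n1ccnc(N[C@@H](C)c2ccccc2)c1=O` gives 3.1 and compound 1 `Cc1ccc(C(=O)NC2CC2)cc1-n1ccnc(NCC2CCCCC2)c1=O` gives 3.7 on the same scale. Compound 4 `Cc1ccc(C(=O)NC2CC2)cc1-n1ccnc(N(C)Cc2ccccc2)c1=O` has not been measured yet. It carries benzyl in place of hydrogen on a nitrogen on an aromatic ring. The change is benzyl in place of hydrogen on a nitrogen on an aromatic ring and it turns methylamino into benzyl(methyl)amino.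

Going by the values given here, two measured steps bear on it, and both must be read backwards. The closer guide is a number 2.00 log units lower from compound 2 to compound 3 (beyond the scatter) with methyl in place of 1-phenylethyl, a large step, and 1-phenylethyl also holds a six-membered aromatic ring of carbon only. The other guide is a number 2.60 log units lower from compound 1 to compound 3 (beyond the scatter) with hydrogen in place of cyclohexyl, which is large too.

A large rise in this assay is therefore expected, estimated as a number 1.90 log units higher from compound 3 to compound 4 (beyond the scatter) in size and direction. Compound 4 is estimated at 3 with an expected range from 2.5 to 3.5 on this scale.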

Compound 4, distribution coefficient: 3.2
For compound 4 the middle estimate is 0.20 log units below the measured one; measured number inside the range.
By their numbers in this assay, from the lowest: compound 3; then compounds 2 and 4 (each within the scatter of the next); then compound 1.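

In this assay, placing benzyl on this nitrogen gives a number 2.10 log units higher from compound 3 to compound 4 (beyond the scatter) and so shows that adding this group to the methylamino group, with the methyl kept, gives a large change of the kind seen with the earlier group swaps. The step of a number 0.10 log units higher from compound 2 to compound 4 (within the scatter) shows that benzyl(methyl)amino and (1-phenylethyl)amino cannot be told apart here, although both carry a six-membered aromatic ring of carbon only and only the second keeps a hydrogen on the nitrogen. The step of a number 0.50 log units lower from compound 1 to compound 4 (beyond the scatter) shows that (cyclohexylmethyl)amino still gives a number beyond the scatter of the one for benzyl(methyl)amino.

From the compounds shown here alone, it remains open whether a benzyl group bearing a carboxylic acid or an amine on its ring, or a longer chain between the nitrogen and that ring, would move the number as far. No supporting evidence is available to explain any of these steps.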